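Shortening the amine chain on a thiadiazole core

This account rests on a few compounds, and the source may have more. Where it says the series, first, only, none or still open, it means among the compounds named here.

Measured so far:
- compound 1, `CCCCNc1nnc(SCC(=O)N(Cc2cccc([N+](=O)[O-])c2)c2ccc(F)cc2)s1`: 30%
- compound 2, `CC(C)CNc1nnc(SCC(=O)N(Cc2cccc([N+](=O)[O-])c2)c2ccc(F)cc2)s1`: 25.5%
- compound 3, `C=CCNc1nnc(SCC(=O)N(Cc2cccc([N+](=O)[O-])c2)c2ccc(F)cc2)s1`: 32.7%

All three compounds share one core and differ only in the group on a saturated chain carbon bound to a nitrogen on an aromatic ring. In an assay on isolated protein for inhibition of Amine oxidase [flavin-containing] A (Homo sapiens), read by fluorescence and Amplex Red, with a stated time of 30 min, tested at 0.01 uM (a lower number here means a weaker effect, a higher number a stronger effect of the compound at the concentration tested), compound 2 gives 25.5%, the lowest of the three numbers, though its distance to compound 1 and to compound 3 stays within the usual scatter, so no order among them can be read from these values.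

Compound 4, `CCNc1nnc(SCC(=O)N(Cc2cccc([N+](=O)[O-])c2)c2ccc(F)cc2)s1`, has not been measured yet. It differs from compound 2 by methyl in place of isopropyl on a saturated chain carbon bound to a nitrogen on an aromatic ring.

Within the data shown here, two measured steps touch the same place on the core. From compound 1 to compound 2, exchanging propyl for isopropyl, the readout moved by a number 4.5 percentage points lower from compound 1 to compound 2 (within the scatter). From compound 2 to compound 3, exchanging isopropyl for vinyl, it moved by a number 7.2 percentage points higher from compound 2 to compound 3 (within the scatter). Both steps lie within the scatter, and the step from compound 1 to compound 3, a number 2.7 percentage points higher from compound 1 to compound 3 (within the scatter), does too. Swapping one small chain for another at this position has so far produced no change beyond the scatter, and a methyl is expected to behave alike, so the step from compound 2 to compound 4 is expected to be a number 3.5 percentage points higher from compound 2 to compound 4 (within the scatter), with no real direction. Compound 4 is therefore estimated to give 29%, between 18% and 40%.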

Compound 4, a percentage reported as inhibition, at one concentration (the size of the read-out at that concentration, not a potency): 30.3%
Beside the measured number, compound 4's estimate is 1.3 percentage points below it; low and high end bracket the measured number.
By their numbers in this assay, from the lowest: compounds 2, 1, 4 and 3 (each within the scatter of the next).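

In this assay, methyl in place of isopropyl gives a number 4.8 percentage points higher from compound 2 to compound 4 (within the scatter), so taking the branch away and leaving only the ethylamino chain of compound 4 produces no readable change. Methyl in place of vinyl gives a number 2.4 percentage points lower from compound 3 to compound 4 (within the scatter), and hydrogen in place of ethyl, on a saturated chain carbon, two bonds along the chain from a nitrogen on an aromatic ring, gives a number 0.3 percentage points higher from compound 1 to compound 4 (within the scatter), so neither removing the vinyl end nor cutting the straight chain back moves the number beyond the scatter. The earlier compounds shown here compared only chains of similar reach, whereas compound 4 adds a clearly smaller chain, and all four compounds still cannot be put in any order at this position.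

Open, on these data alone, is whether anything very different here would break this flat picture, such as a free amino group with no chain at all, a much longer chain, a cyclohexyl ring or a carboxylic acid at the chain end. No other measurement bears on this flat result, which rests on a single test concentration.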